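Swapping diethylamino for a silicon-bearing group on the shared core

A few compounds are considered here, and "the series" means these few. Any claim that something is new, unique, unknown or untested is made for them only; others in the source may bear on it.

Of the compounds shown here, three with one shared core have numbers so far in a functional assay on HL-60 cells (Homo sapiens) for antiproliferative activity, read by MTT assay, with a stated time of 48 h (a higher number here means a weaker inhibitor, a lower number a stronger inhibitor), and serve as the basis here. Compound 1 (`CC(=O)OC/C1=C/C[C@](C)(CCC=C(C)C)/C=C/[C@@H](OC(=O)C=C(C)C)[C@](C)(O)/C=C/C1=O`) gives 2950 nM in this readout, and compound 2 (`COC/C1=C/C[C@](C)(CCC=C(C)C)/C=C/[C@@H](OC(=O)C=C(C)C)[C@](C)(O)/C=C/C1=O`) gives 3070 nM there. Their step is a 1.0-fold higher number from compound 1 to compound 2 (0.02 log units; within the scatter) and does not separate them. Compound 3 (`CCN(CC)C/C1=C/C[C@](C)(CCC=C(C)C)/C=C/[C@@H](OC(=O)C=C(C)C)[C@](C)(O)/C=C/C1=O`) gives 140 nM and holds the lowest number of the three.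

Compound 4 (`CC(C)=CCC[C@]1(C)/C=C/[C@@H](OC(=O)C=C(C)C)[C@](C)(O)/C=C/C(=O)/C(C[Si](C)(C)C(C)(C)C)=C\C1`) differs from compound 3 by a group of 7 heavy atoms (6 carbon, 1 silicon; no ring) in place of a group of 5 heavy atoms (4 carbon, 1 nitrogen; no ring), on a saturated chain carbon bound to a double-bonded ring carbon and so no longer carries diethylamino. Among the measured compounds shown here, two measured steps bear on this change. Both a 21-fold lower number from compound 1 to compound 3 (1.32 log units; beyond the scatter) and a 22-fold lower number from compound 2 to compound 3 (1.34 log units; beyond the scatter) are large, and both end at the diethylamino group of compound 3. Compound 4 leaves that group, so a large step in the opposite direction is expected, toward the numbers of compound 1 and compound 2. For the measured compounds named here, no compound with a silicon-bearing group has been measured, which keeps the range wide. The expected move is a 14-fold higher number from compound 3 to compound 4 (1.15 log units; beyond the scatter) and remains an estimate. For compound 4 the estimated value is 2000 nM with an expected range of 500 nM to 7000 nM as the working figure.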

Compound 4, half-maximal inhibitory concentration: 2770 nM
Compound 4: middle estimate off by 1.4-fold (0.14 log units), on the low side; measured number inside the range.
By their numbers in this assay, from the lowest: compound 3; then compounds 4, 1 and 2 (each within the scatter of the next).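

In this assay, the step of a 20-fold higher number from compound 3 to compound 4 (1.30 log units; beyond the scatter) shows that this position does not keep the low number of compound 3 when a group of 7 heavy atoms (6 carbon, 1 silicon; no ring) replaces diethylamino on the saturated chain carbon. Among the compounds shown here, the steps of a 1.1-fold lower number from compound 2 to compound 4 (0.04 log units; within the scatter) and a 1.1-fold lower number from compound 1 to compound 4 (0.03 log units; within the scatter) are both within the scatter, so the silicon-bearing group, methoxy and acetoxy cannot be separated here, and among the four compounds only the one with diethylamino stands apart. Having more heavy atoms than diethylamino therefore does not by itself bring the number down at this position, and no measured information bears on what sets diethylamino apart from the other three groups.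

The compounds shown leave open whether the low number belongs to amines at this position in general, as a dimethylamino, a morpholine or a primary amine would test. They also leave open whether an all-carbon counterpart of the silicon-bearing group, such as a neopentyl chain, or a carboxylic acid would stay with compounds 1, 2 and 4.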